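This account rests on a few compounds, and the source may have more. Where it says the series, first, only, none or still open, it means among the compounds named here.

Measured compounds:
- compound 1 `COc1cc(/C=C2\CCC/C(=C\c3ccccc3Br)C2=O)cc(OC)c1OC` gives 2700 nM in a functional assay on NCI-H508 cells (Homo sapiens) for antiproliferative activity, read by MTT assay, with a stated time of 72 h; a lower number here means a stronger inhibitor, a higher number a weaker inhibitor
- compound 2 `COc1cc(/C=C2\CCC/C(=C\c3cccc(O)c3)C2=O)cc(OC)c1OC` gives 5600 nM in this assay
- compound 3 `COc1cc(/C=C2\CCC/C(=C\c3ccc(F)c(F)c3)C2=O)cc(OC)c1OC` gives 4000 nM in this assay

Compound 3 stands second highest of the three numbers. Its two neighbours are both within the scatter of it: compound 2 sits a 1.4-fold lower number from compound 2 to compound 3 (0.15 log units; within the scatter) and compound 1 sits a 1.5-fold higher number from compound 1 to compound 3 (0.17 log units; within the scatter), so the three measured compounds cannot be ordered with confidence against one another.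

Compound 4 `COc1cc(/C=C2\CCC/C(=C\c3ccc(O)c(Cl)c3)C2=O)cc(OC)c1OC` is not yet measured in this assay. The change from compound 3 is 3-chloro-4-hydroxyphenyl in place of 3,4-difluorophenyl on a double-bonded chain carbon bound to a double-bonded ring carbon. Among the compounds with values here, the only step on record that touches a hydroxyl on this phenyl is a 2.1-fold higher number from compound 1 to compound 2 (0.32 log units; beyond the scatter), which is modest and the one step here beyond the scatter. The step of a 1.4-fold lower number from compound 2 to compound 3 (0.15 log units; within the scatter) removes that hydroxyl and is within the scatter. Within the data shown here, no measured step carries a chlorine on this phenyl, so the entering group is only partly covered.

Taken together, a hydroxyl-bearing phenyl at this place has so far given a somewhat higher number, while the difference against a halogenated phenyl stayed within the scatter. Compound 4 is therefore expected to give a number near compound 3 or slightly higher, with the step of a 1.3-fold higher number from compound 3 to compound 4 (0.10 log units; within the scatter) expected to remain within the scatter. The estimate for compound 4 in this assay is 5000 nM, with a range from 2500 nM to 10000 nM.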

Compound 4, half-maximal inhibitory concentration: 4000 nM
Compound 4: middle estimate off by 1.3-fold (0.10 log units), on the high side; measured number inside the range.
By their numbers in this assay, from the lowest: compounds 1, 3, 4 and 2 (each within the scatter of the next, the first and the last beyond it).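

In this assay the exchange of 3,4-difluorophenyl for 3-chloro-4-hydroxyphenyl on a double-bonded chain carbon bound to a double-bonded ring carbon gives no change at the digits printed from compound 3 to compound 4 (within the scatter), even though the entering group carries a hydrogen-bond donor and a hydrogen-bond acceptor that the leaving group lacks, so these counts do not separate the two compounds here. Within the data shown here, the new group also stays close to the other two substituted phenyls, with a 1.4-fold lower number from compound 2 to compound 4 (0.15 log units; within the scatter) and a 1.5-fold higher number from compound 1 to compound 4 (0.17 log units; within the scatter), which leaves a 2.1-fold higher number from compound 1 to compound 2 (0.32 log units; beyond the scatter) as the only step in the set beyond the scatter. No measurement at hand bears on why this position tolerates these phenyls without a clearer separation.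

On these data alone, whether an amine or a carboxylic acid on this phenyl, or a longer chain in its place, would give a step beyond the scatter remains open. As far as these compounds go, all four compounds share the rest of the core and were read on a single cell line, so the role of that remainder and the behaviour of the series in other cells also remain open.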